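This account rests on a few compounds, and the source may have more. Where it says the series, first, only, none or still open, it means among the compounds named here.

Three amides of the same cinnamoyl type have been measured in a functional assay on the whole organism for inhibition, with Brassica rapa subsp. chinensis as the target, with a stated time of 3 days, tested at 100 ppm; a higher number here means more inhibition of growth at the concentration tested, a lower number less inhibition of growth. Compound 1 `CCCCCCNC(=O)/C=C/c1ccccc1` carries a hexyl chain on the amide nitrogen and gives 55%. Compound 3 `CCCCCCCCNC(=O)/C=C/c1ccccc1` carries an octyl chain and gives 34%, which places it second highest of the three, beyond the scatter below compound 1 and beyond the scatter above compound 2 `CCCCCCCCCCNC(=O)/C=C/c1ccccc1`, the decyl analogue, which gives 10%.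

Compound 4 `CCCCCCCCCCCCNC(=O)/C=C/c1ccccc1`, the dodecyl analogue, has not yet been measured. It differs from compound 3 by butyl in place of hydrogen on a saturated chain carbon, eight bonds along the chain from an amide-type nitrogen, so the chain on the nitrogen grows by four carbons.

For the measured compounds named here, two measured steps bear on this change. Lengthening the chain by two carbons at the same place gave a number 24 percentage points higher from compound 2 to compound 3 (beyond the scatter), read in reverse. Lengthening the chain by four carbons two bonds nearer the nitrogen gave a number 45 percentage points lower from compound 1 to compound 2 (beyond the scatter). Both point the same way: each lengthening of the chain has lowered the number, and the longer addition lowered it more.

For compound 4 a further fall in this assay is therefore expected, of about a number 26 percentage points lower from compound 3 to compound 4 (beyond the scatter), with the floor of the read-out limiting how far it can go. The estimate for compound 4 is 8%, with a range from 0% to 22%.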

Compound 4, percent growth inhibition at one concentration: 48%
Compound 4: the middle estimate sits 40 percentage points below what was measured; the whole stated range lies below it.
By their numbers in this assay, from the lowest: compound 2; then compound 3; then compounds 4 and 1 (each within the scatter of the next).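

In this assay, butyl in place of hydrogen at this position eight bonds along the chain from an amide-type nitrogen gives a number 14 percentage points higher from compound 3 to compound 4 (beyond the scatter), so the effect of adding carbons depends on where the chain already ends, and the same change six bonds along ran the other way: the same change on two cores in this assay, a number 45 percentage points lower (beyond the scatter) from compound 1 to compound 2 and a number 14 percentage points higher (beyond the scatter) from compound 3 to compound 4, 59 percentage points apart, beyond the scatter of two such steps Ethyl in place of hydrogen shows the same dependence on the length of the starting chain: the same change on two cores in this assay, a number 21 percentage points lower (beyond the scatter) from compound 1 to compound 3 and a number 38 percentage points higher (beyond the scatter) from compound 2 to compound 4, 59 percentage points apart, beyond the scatter of two such steps The four chains therefore do not form a steady decline: the decyl chain of compound 2 gives the lowest number of the set, the series climbs again with a number 38 percentage points higher from compound 2 to compound 4 (beyond the scatter), and the dodecyl and hexyl chains cannot be told apart, with a number 7 percentage points lower from compound 1 to compound 4 (within the scatter).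

The compounds shown leave open what a longer chain such as tetradecyl would give, and whether a nonyl or undecyl chain would make the dip around compound 2 look sharp or gradual. They also do not explain the rise, and they cannot tell whether a hydroxyl group at the end of the chain would change this pattern.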